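The compounds below may be only part of what the source reports. "The series", "measured", "known", "first", "only" and "open" are said of these compounds alone.

Measured compounds:
compound 1, `COc1cc(CNC(=S)NCC(COC(=O)C(C)(C)C)Cc2ccc(C)c(C)c2)c(Cl)cc1O`, 24.2 nM
compound 2, `COc1cc(CNC(=S)NCC(COC(=O)C(C)(C)C)Cc2ccc(C)c(C)c2)c(Br)cc1O`, 19.9 nM
compound 3, `COc1cc(CNC(=S)NC(CCc2ccc(C(C)(C)C)cc2)COC(=O)C(C)(C)C)cc(Cl)c1O`, 122 nM

In an assay on CHO cells for displacement of a labelled ligand from transient receptor potential cation channel subfamily V member 1 (Rattus norvegicus) (on this read-out lower numbers stand for stronger inhibition and higher numbers for weaker inhibition), compound 1 gives 24.2 nM and compound 2 gives 19.9 nM. The two differ by bromo in place of chloro on an aromatic carbon, and that change made a 1.2-fold lower number from compound 1 to compound 2 (0.08 log units; within the scatter). Compound 3 gives 122 nM in this assay, the highest number among the three measured compounds. The difference between the core of compound 3 and the core of compound 1 is not broken down here.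

Compound 4, `COc1cc(CNC(=S)NC(CCc2ccc(C(C)(C)C)cc2)COC(=O)C(C)(C)C)cc(Br)c1O`, has not been measured. It differs from compound 3 by bromo in place of chloro on an aromatic carbon. This is the same kind of change as that from compound 1 to compound 2, but not the same: in compound 1 the changed carbon is ortho to a large group, meta to a hydroxy group and para to a methoxy group, whereas in compound 3 it is ortho to a hydroxy group, meta to a large group and meta to a methoxy group. Going by the values given here, only one earlier instance of this change exists, so the expectation rests on a single step.

Because a 1.2-fold lower number from compound 1 to compound 2 (0.08 log units; within the scatter) stayed within the scatter, compound 4 is expected to give 105 nM in this assay, somewhere between 55 nM and 220 nM. That estimate means a 1.2-fold lower number from compound 3 to compound 4 (0.07 log units; within the scatter), a step expected to remain within the scatter.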

Compound 4, inhibition constant: 143 nM
Compound 4: the middle estimate sits 1.4-fold (0.13 log units) below what was measured; measured number inside the range.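

In this assay, bromo in place of chloro on the core of compound 3 gave a 1.2-fold higher number from compound 3 to compound 4 (0.07 log units; within the scatter). Set beside the earlier instance, the change reads alike on the two cores, even though the groups around the changed carbon are not the same: the same change on two cores in this assay, a 1.2-fold lower number (0.08 log units; within the scatter) from compound 1 to compound 2 and a 1.2-fold higher number (0.07 log units; within the scatter) from compound 3 to compound 4, 1.4-fold (0.15 log units) apart, within the scatter of two such steps. This shows that, in these two pairs, exchanging chloro for bromo left the number within the scatter on both cores, so the earlier step carried over to this second core, but two pairs make no rule for other cores in the series, and steps this small cannot show whether the exchange has any effect of its own.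

The compounds shown leave open whether fluoro, iodo, a methyl group or plain hydrogen on that aromatic carbon would read like chloro and bromo on either core. They also leave open which of the several differences between the two cores separates the numbers of the two pairs.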